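Swapping the Aryl Group on a Urea in Two Cores

A few compounds are considered here, and "the series" means these few. Any claim that something is new, unique, unknown or untested is made for them only; others in the source may bear on it.

Compound 1, `CCNc1cc(-c2ccc(NC(=O)Nc3cccc(Cl)c3)cc2C)ccn1`, in an assay on isolated protein for inhibition of serine/threonine-protein kinase PLK1 (Homo sapiens), read by radiometric assay and 33P incorporation, with a stated time of 40 min, tested at 20 uM, in the presence of a further agent that is not named here (a lower number here means less inhibition, a higher number more inhibition at the concentration tested (going by the name of the read-out)), gives 82.7%.
Compound 2, `CCNc1cc(-c2ccc(NC(=O)Nc3ccc(C(F)(F)F)cc3)cc2C)ccn1`, in this assay gives 54.8%.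
Compound 3, `O=C(Nc1cccc(Cl)c1)Nc1ccc(-c2ccnc(NCC3CC3)c2)c(C(F)(F)F)c1`, in this assay gives 63.8%.

Compound 1 and compound 2 differ in one place only: 4-(trifluoromethyl)phenyl in place of 3-chlorophenyl on an amide-type nitrogen. That single change made a number 27.9 percentage points lower from compound 1 to compound 2 (beyond the scatter). Compound 3 carries a different core, and the difference between the core of compound 1 and the core of compound 3 is not broken down here; the value of compound 3 lies within the scatter of compound 2 and beyond the scatter from compound 1.

Compound 4, `O=C(Nc1ccc(C(F)(F)F)cc1)Nc1ccc(-c2ccnc(NCC3CC3)c2)c(C(F)(F)F)c1`, is not yet measured. It is related to compound 3 by 4-(trifluoromethyl)phenyl in place of 3-chlorophenyl on an amide-type nitrogen, which is the same change that turns compound 1 into compound 2, made at the same place. Compound 4 is expected to show a number 24.8 percentage points lower from compound 3 to compound 4 (beyond the scatter), because the step of a number 27.9 percentage points lower from compound 1 to compound 2 (beyond the scatter) was a modest drop and the same change on the core of compound 3 is expected to behave alike. Compound 4 is therefore estimated at 39% in this assay, with a likely range from 20% to 58%.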

Compound 4, a percentage reported as inhibition, at one concentration (the size of the read-out at that concentration, not a potency): 53.4%
Estimate against measurement, compound 4: 14.4 percentage points below; the measured number falls inside the stated range.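

On the core of compound 3, placing 4-(trifluoromethyl)phenyl in place of 3-chlorophenyl on the amide-type nitrogen again lowers the number in this assay, with a number 10.4 percentage points lower from compound 3 to compound 4 (beyond the scatter). The direction of the change therefore holds on both cores, but its size does not carry over, as the two steps set side by side show: the same change on two cores in this assay, a number 27.9 percentage points lower (beyond the scatter) from compound 1 to compound 2 and a number 10.4 percentage points lower (beyond the scatter) from compound 3 to compound 4, 17.5 percentage points apart, beyond the scatter of two such steps. These two pairs do not show why the size differs, which of the differences between the two cores matters, or how the change would behave on a third core.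

The compounds shown carry only 3-chlorophenyl and 4-(trifluoromethyl)phenyl on this nitrogen, leaving open how a phenyl ring bearing a methoxy group, an amine or a carboxylic acid would fare on either core. Going by these compounds, each number also comes from a single concentration, and how the compounds would compare in potency remains open.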